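The source may hold more compounds than are shown below. What is called first, only, known or untested is meant among the compounds shown, and "the series" means these compounds.

Measured in a functional assay on the whole organism (stomach) for inhibition, with Canis familiaris (Canis lupus familiaris) as the target, at a dose of 5 mg/kg by the intravenous route; a lower number here means a weaker effect, a higher number a stronger effect of the compound at the dose given:
- compound 1 `CC(=O)c1c(C)nc2c(OCc3ccccc3)cccn12`: 9%
- compound 2 `Cc1nc2c(OCc3ccccc3)cccn2c1CS(C)(=O)=O`: 0%
- compound 3 `COC(=O)Cc1c(C)nc2c(OCc3ccccc3)cccn12`: 16%

Compound 1 stands second highest of the three, its gaps to both neighbours within the scatter: a number 7 percentage points higher from compound 1 to compound 3 (within the scatter) and a number 9 percentage points lower from compound 1 to compound 2 (within the scatter). Going by the values given here, only the step of a number 16 percentage points higher from compound 2 to compound 3 (beyond the scatter) exceeds the scatter.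

Going by these compounds, compound 4 `Cc1nc2c(OCc3ccccc3)cccn2c1COC(=O)N(C)C` is untested. Relative to compound 1 the change is ((dimethylcarbamoyl)oxy)methyl in place of acetyl on an aromatic carbon. The two steps that bear on it both replace acetyl at the same carbon, and both stayed within the scatter, so no step beyond the scatter is expected here either, in this assay.

Compound 4 is therefore expected near 10%, between 0% and 25%. The step this implies, a number 1 percentage points higher from compound 1 to compound 4 (within the scatter), is estimated as flat.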

Compound 4, a percentage reported as inhibition, in the whole organism at one dose (the size of the read-out at that dose, not a potency): 23%
Beside the measured number, compound 4's estimate is 13 percentage points below it, within the range that was stated.
By their numbers in this assay, from the lowest: compounds 2, 1, 3 and 4 (each within the scatter of the next, the first and the last beyond it).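

In this assay the change to ((dimethylcarbamoyl)oxy)methyl gives a number 14 percentage points higher from compound 1 to compound 4 (beyond the scatter) and is the only replacement of acetyl at this aromatic carbon shown to exceed the scatter. The step of a number 23 percentage points higher from compound 2 to compound 4 (beyond the scatter) also exceeds it, while a number 7 percentage points higher from compound 3 to compound 4 (within the scatter) does not, so (dimethylcarbamoyl)oxy and methoxycarbonyl on the saturated chain carbon cannot be separated in this read-out. No available data explain the gain over acetyl.

Open, going by these compounds, is whether an amine or a carboxylic acid on that chain carbon, or a longer chain carrying (dimethylcarbamoyl)oxy, would go beyond compound 4. Also open, on these data alone, is how these compounds compare at other doses.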